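Adding a second methoxy to the aryl ring of compound 1

A few compounds are considered here, and "the series" means these few. Any claim that something is new, unique, unknown or untested is made for them only; others in the source may bear on it.

Of the compounds shown here, two have been measured in a functional assay on SF-539 cells (Homo sapiens) for cytotoxicity, read by sulforhodamine B assay, with a stated time of 48 h, tested at 0.01 uM; on this read-out lower numbers stand for a stronger effect and higher numbers for a weaker effect at the one concentration tested. Compound 1, with the structure `COc1ccc(-c2cc(/C=C/C(=O)c3ccc(N)cc3)[nH]n2)cc1`, gives 98% in this assay. Compound 2, with the structure `COc1cc(-c2cc(/C=C/C(=O)c3ccc(Cl)c(Cl)c3)[nH]n2)cc(OC)c1OC`, gives 93% in this assay. The gap between the two numbers lies within the usual scatter of this kind of measurement, so compound 1 stands alongside compound 2 rather than apart from it, and both leave the cells largely unharmed at this single concentration.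

Compound 3, with the structure `COc1ccc(-c2cc(/C=C/C(=O)c3ccc(N)cc3)[nH]n2)cc1OC`, has not yet been measured. It differs from compound 1 in one place: methoxy in place of hydrogen on an aromatic carbon. For the measured compounds named here, no measured pair shows what such a change does in this assay, so the expectation rests on how little room the numbers of compound 1 and compound 2 leave for movement.

The step in this assay is expected to be small, from compound 1 to compound 3 amounting to a number 2 percentage points lower from compound 1 to compound 3 (within the scatter), which is none beyond the scatter. Compound 3 is therefore expected to give about 96% in this assay, estimated to fall between 85% and 105%.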

Compound 3, a percentage reported as activity, at one concentration (the size of the read-out at that concentration, not a potency): 93%
Compound 3: middle estimate off by 3 percentage points, on the high side; the range from low to high includes it.
By their numbers in this assay, from the lowest: compounds 2, 3 and 1 (each within the scatter of the next).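

For the compounds shown here, the pair of compound 1 and compound 3 is the first here that differs in only one place, and it gives a direct reading of methoxy in place of hydrogen on an aromatic carbon, ortho to a methoxy group and meta to a large group. In this assay, going by these compounds alone, this change amounts to a number 5 percentage points lower from compound 1 to compound 3 (within the scatter), so the added methoxy at this position produces no step that can be told apart from the scatter of repeated measurements. Within the data shown here, this shows only that the two compounds cannot be separated at this single concentration, and nothing available here explains the result or ties it to any property of the methoxy group.

The compounds shown leave open whether a hydroxyl group, an ethoxy group or a fluorine atom at this same position would give a step beyond the scatter. They also leave open whether methoxy at this position would matter at a concentration where the shared core has a stronger effect on the cells, since a single reading near the weak end of the scale says little about the effect at other concentrations.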